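The source may report more compounds than this note shows. Statements on the series, on what has been measured and on what is new or still open speak of the compounds shown alone.

Measured so far:
compound 1, `O=C1NC(=O)/C(=C/c2ccc(OCCSc3nnc(Cc4ccccc4)[nH]3)cc2)S1`: 38.3%
compound 2, `Cc1ccc(-c2nnc(SCCOc3ccc(/C=C4\SC(=O)NC4=O)cc3)[nH]2)cc1`: 40.3%

Both compounds were tested in a functional assay on the whole organism (strain Wistar) with Rattus norvegicus as the target, with a stated time of 15 days, at a dose of 30 mg/kg by the oral route; on this read-out lower numbers stand for a weaker effect and higher numbers for a stronger effect at the one dose given. Compound 1 gives 38.3%, and compound 2 gives 40.3%; the two values lie within the usual scatter of each other, so neither can be called the stronger one. Compound 1 and compound 2 share a core and differ at a single place, where the benzyl of compound 1 is replaced by 4-methylphenyl; that change gave a number 2 percentage points higher from compound 1 to compound 2 (within the scatter).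

Compound 3, `O=C1NC(=O)/C(=C/c2ccc(OCCSc3nnc(-c4ccc(Br)cc4)[nH]3)cc2)S1`, has not yet been tested in this assay. It differs from compound 1 in one place: 4-bromophenyl in place of benzyl on an aromatic carbon. Among the measured compounds shown here, the one measured step that bears on it, swapping the same benzyl for a six-membered aromatic ring, stayed within the scatter. A step of similar size, so none beyond the scatter, is therefore expected here: a number 1.7 percentage points higher from compound 1 to compound 3 (within the scatter). Compound 3 is estimated at 40%, with a likely range from 28% to 52%.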

Compound 3, a percentage reported as activity, at one dose (the size of the read-out at that dose, not a potency): 39.5%
Compound 3: middle estimate off by 0.5 percentage points, on the high side, and the stated range covers the measured number.
By their numbers in this assay, from the lowest: compounds 1, 3 and 2 (each within the scatter of the next).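

In this assay, 4-bromophenyl in place of benzyl gave a number 1.2 percentage points higher from compound 1 to compound 3 (within the scatter) and bromo in place of methyl gave a number 0.8 percentage points lower from compound 2 to compound 3 (within the scatter) on the same core. Compound 2 had shown only a methyl-bearing ring at this aromatic carbon of the five-membered ring, and compound 3 now shows that a bromine-bearing ring cannot be told apart from it or from the benzyl of compound 1 at this one dose. No measurement shown here offers an explanation for these close readings.

From the compounds shown here alone, whether this position would respond to a group of a different kind, such as an amine or a carboxylic acid, remains open. A longer chain in place of benzyl also remains untested among the compounds shown, so it is unknown whether any change at this carbon can separate from these three.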